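A few compounds are considered here, and "the series" means these few. Any claim that something is new, unique, unknown or untested is made for them only; others in the source may bear on it.

Measured so far in an assay on HEK293 cells for displacement of a labelled ligand from 5-hydroxytryptamine receptor 6 (Homo sapiens), read by radioligand binding, with a stated time of 60 min, tested at 100 nM; on this read-out lower numbers stand for less inhibition and higher numbers for more inhibition at the one concentration tested (going by the name of the read-out):
- compound 1 `CN(C)CCn1c(=O)sc2cc(NS(=O)(=O)c3ccc4ccccc4c3)ccc21` gives 22%
- compound 2 `O=c1sc2cc(NS(=O)(=O)c3ccc4ccccc4c3)ccc2n1CCN1CCCC1` gives 0%
- compound 3 `CN(C)CCn1c(=O)sc2cc(S(=O)(=O)N(C)c3cccc4ccccc34)ccc21` gives 0%

Compound 1 and compound 2 share one core and differ only in the amine at the end of the side chain: pyrrolidin-1-yl in place of dimethylamino on a saturated chain carbon, two bonds along the chain from an aromatic nitrogen. The measured step is a number 22 percentage points lower from compound 1 to compound 2 (beyond the scatter).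

Compound 3 is built on another core; the difference between the core of compound 1 and the core of compound 3 is not broken down here. In this assay compound 3 and compound 2 sit within the usual scatter of each other, and compound 1 is the only one of the three with a reading clearly above them.

Compound 4 `CN(c1cccc2ccccc12)S(=O)(=O)c1ccc2c(c1)sc(=O)n2CCN1CCCC1` has not been measured. It differs from compound 3 by pyrrolidin-1-yl in place of dimethylamino on a saturated chain carbon, two bonds along the chain from an aromatic nitrogen. Among the compounds with values here, this is the same change as the one from compound 1 to compound 2, made at the same place, so the pair compound 1 to compound 2 is the only guide to its size.

Because compound 3 already gives 0%, there is little room for a downward step of the kind seen in a number 22 percentage points lower from compound 1 to compound 2 (beyond the scatter), and the expected step is no change at the digits printed from compound 3 to compound 4 (within the scatter). The estimate for compound 4 in this assay is 0%, with an expected range from -10% to 10%. This rests on one measured pair only, so the expectation is loose.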

Compound 4, a percentage reported as inhibition, at one concentration (the size of the read-out at that concentration, not a potency): 40%
The estimate for compound 4 lay 40 percentage points below the measured number; the measured number lies above the stated range.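

In this assay, pyrrolidin-1-yl in place of dimethylamino on a saturated chain carbon, two bonds along the chain from an aromatic nitrogen, gives a number 40 percentage points higher from compound 3 to compound 4 (beyond the scatter). On these two cores the same change therefore has neither a fixed size nor a fixed direction, so the step measured on one core does not transfer to the other: the same change on two cores in this assay, a number 22 percentage points lower (beyond the scatter) from compound 1 to compound 2 and a number 40 percentage points higher (beyond the scatter) from compound 3 to compound 4, 62 percentage points apart, beyond the scatter of two such steps

This shows that, within these two pairs, the outcome of the amine change depends on the core it sits on, but it does not show which part of the difference between the core of compound 1 and the core of compound 3 decides the direction, and two pairs give no rule for any further core.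

Open, going by these compounds, is whether the reversal extends to other amines at the end of the chain, such as a piperidine or a morpholine, or to a longer chain carrying the same pyrrolidine on either core. Also open, on these data alone, is how the reading of compound 4 translates into potency, as these numbers are inhibition at one concentration only.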